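Sulfonyl substituent trimming in the aryl-alkyne acid series

The source may report more compounds than this note shows. Statements on the series, on what has been measured and on what is new or still open speak of the compounds shown alone.

Among the measured compounds shown here, compound 1, `COCCN(C)S(=O)(=O)c1ccc(C)c(C#Cc2cc(Cl)ccc2OCC(=O)O)c1`, is the only member of the series with a reading in an ADME assay on a cell-free system (plasma, Rattus norvegicus) (a higher number here means a larger unbound share of the compound, a lower number a smaller unbound share), where compound 1 gives 0.007. Compound 2, `COCCNS(=O)(=O)c1ccc(C)c(C#Cc2cc(Cl)ccc2OCC(=O)O)c1`, was run in the same setting, but in this assay compound 2 gives "not determined" (no result reported), so compound 2 stands without a value. Compound 3, `Cc1ccc(S(C)(=O)=O)cc1C#Cc1cc(Cl)ccc1OCC(=O)O`, has not yet been measured. The change from compound 2 to compound 3 is methyl in place of (2-methoxyethyl)amino on a sulfonyl sulfur. For the measured compounds named here, with no step between measured compounds available, the size of this step in this assay cannot be anchored; a move toward a larger unbound share is expected, but likely one that does not clear the usual scatter. Taking compound 1 at 0.007 as the only reference point, compound 3 is expected to give 0.012, within a range of 0.004 to 0.04.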

Compound 3, unbound fraction: 0.014
Estimate against measurement, compound 3: 1.2-fold (0.07 log units) below; the measured number falls inside the stated range.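

In this assay, among the compounds shown here, methyl in place of (2-methoxyethyl)(methyl)amino on a sulfonyl sulfur gives a 2.0-fold higher number from compound 1 to compound 3 (0.30 log units; within the scatter) and is the first step that can be read at this position. The substituent on the sulfonyl sulfur can therefore be cut back to a single methyl without the unbound fraction leaving the scatter in this pair, while any step involving compound 2 cannot be read, as compound 2 has no number. Nothing at hand bears on what lies behind this reading.

Open, as far as these compounds go, is whether a single pair speaks for the position as a whole, since only methyl and the (2-methoxyethyl)(methyl)amino group can be compared here. A plain amino group, a morpholine or a longer alkyl chain on the sulfonyl sulfur could still give a step beyond the scatter.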